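A few compounds are considered here, and "the series" means these few. Any claim that something is new, unique, unknown or untested is made for them only; others in the source may bear on it.

Compounds measured in a functional assay on aorta (Rattus norvegicus, strain Wistar) for inhibition, with a stated time of 60 min (on this read-out lower numbers stand for smaller maximal responses and higher numbers for larger maximal responses), so far:
compound 1 `FC(F)(F)c1ccc2[nH]c(-c3ccccc3)nc2c1`: 75.6%
compound 2 `CC(C)Oc1ccccc1-c1nc2cc([N+](=O)[O-])ccc2[nH]1`: 31.7%
compound 3 `CCOc1ccccc1-c1nc2cc(C(F)(F)F)ccc2[nH]1`: 19.8%

Compound 3 gives the lowest maximal response of the three. Its nearest neighbour is compound 2, whose number is higher by a margin beyond the scatter; compound 1 lies furthest away, with a much larger maximal response. Going by the values given here, the only single-point step measured in the set runs a number 55.8 percentage points lower from compound 1 to compound 3 (beyond the scatter).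

Compound 4 `CCOc1ccccc1-c1nc2cc([N+](=O)[O-])ccc2[nH]1` is the next to be measured. It is obtained from compound 3 by the change (nitro in place of trifluoromethyl on an aromatic carbon). Among the compounds with values here, no measured step in the set exchanges trifluoromethyl for nitro on the shared core, so the step from compound 1 to compound 3 does not bear on it; that step concerns ethoxy only. Within the data shown here, compound 2 carries nitro with isopropoxy and shows a modest maximal response, but no single step connects it to compound 4.

With nothing to anchor a direction, the expectation for compound 4 is a step of a number 5.2 percentage points higher from compound 3 to compound 4 (within the scatter) in this assay, within the scatter. The estimated maximal response of compound 4 is therefore 25%, with a range from 10% to 45%.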

Compound 4, largest response reached (Emax), in percent of the reference or control that the assay uses: 46.4%
Estimate against measurement, compound 4: 21.4 percentage points below; measured number outside the range, above it.
By their numbers in this assay, from the lowest: compound 3; then compound 2; then compound 4; then compound 1.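

In this assay the aromatic carbon of the shared core that carries trifluoromethyl responds to exchange of its group: with ethoxy held constant, nitro in place of trifluoromethyl gives a number 26.6 percentage points higher from compound 3 to compound 4 (beyond the scatter). The alkoxy group also counts with nitro held constant, since hydrogen in place of methyl on the saturated chain carbon bound to the oxygen gives a number 14.7 percentage points higher from compound 2 to compound 4 (beyond the scatter). Nothing available accounts for either step.

Going by these compounds, whether an amine or a carboxylic acid on this aromatic carbon would give a maximal response nearer that of trifluoromethyl or that of nitro remains open. On these data alone, it is also open how a longer chain on the oxygen would compare with ethoxy and isopropoxy, and whether the order of those two holds with trifluoromethyl on the core.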